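The source may report more compounds than this note shows. Statements on the series, on what has been measured and on what is new or still open speak of the compounds shown alone.

The measured compounds, in an assay on CHO cells for displacement of a labelled ligand from adenosine receptor A1 (Homo sapiens), tested at 10 uM; a lower number here means less inhibition, a higher number more inhibition at the concentration tested (going by the name of the read-out):

compound 1 `O=C(Nc1ccc(Cl)cc1)Nc1nn(-c2ccccc2)c(=O)c2ccccc12` — 10%
compound 2 `COc1ccc(C(=O)Nc2nn(-c3ccccc3)c(=O)c3ccccc23)cc1` — 0%
compound 3 `O=C(NCc1ccccc1)Nc1nn(-c2ccccc2)c(=O)c2ccccc12` — 20%

Compound 1 stands second highest of the three numbers. Its nearest neighbour is compound 2, with a number 10 percentage points lower from compound 1 to compound 2 (within the scatter); its furthest is compound 3, with a number 10 percentage points higher from compound 1 to compound 3 (within the scatter). Both of these steps fall within the scatter, so no order among compound 1 and its two neighbours can be read from them. Within the data shown here, the only step beyond the scatter is a number 20 percentage points higher from compound 2 to compound 3 (beyond the scatter), a modest one.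

Compound 4 `COc1ccccc1CNC(=O)Nc1nn(-c2ccccc2)c(=O)c2ccccc12` differs from compound 1 in one place: 2-methoxybenzyl in place of 4-chlorophenyl on an amide-type nitrogen. The step that bears on this change is a number 10 percentage points higher from compound 1 to compound 3 (within the scatter), where a benzyl likewise replaced the 4-chlorophenyl on the amide-type nitrogen and the number moved only within the scatter. Among the measured compounds shown here, nothing among the measured compounds shows the effect of the 2-methoxybenzyl itself. Compound 4 is therefore expected to give about 20% in this assay, with a range from 5% to 40%. This estimate means an expected step of a number 10 percentage points higher from compound 1 to compound 4 (within the scatter), which would lie within the scatter.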

Compound 4, a percentage reported as inhibition, at one concentration (the size of the read-out at that concentration, not a potency): 28%
Compound 4: the middle estimate sits 8 percentage points below what was measured, and the stated range covers the measured number.
By their numbers in this assay, from the lowest: compounds 2, 1, 3 and 4 (each within the scatter of the next, the first and the last beyond it).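

In this assay the change on this amide-type nitrogen now gives a number 18 percentage points higher from compound 1 to compound 4 (beyond the scatter) and so passes the scatter, which the plain benzyl did not do, and the comparison with the 4-methoxyphenyl on the carbonyl carbon gives a number 28 percentage points higher from compound 2 to compound 4 (beyond the scatter) as well. The methoxy cannot be credited with this on its own: its direct step is a number 8 percentage points higher from compound 3 to compound 4 (within the scatter) and does not separate the two benzyl compounds. Nothing measured here explains why the number moves.

The compounds shown leave open whether a longer chain on this nitrogen, such as 2-phenylethyl, would carry the number further. They also leave open what a hydroxy or an amine on the benzyl ring would do in place of the methoxy.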